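The compounds below may be only part of what the source reports. "The series", "measured", "known", "first", "only" and "open" are said of these compounds alone.

In a functional assay on HepG2 cells (Homo sapiens) for inhibition, read by sulforhodamine B assay, with a stated time of 74 h (on this read-out higher numbers stand for weaker inhibition and lower numbers for stronger inhibition), compound 1 (`O=C1C=CC2(C=C1)OCC(=O)N2S(=O)(=O)c1ccccc1`) gives > 10000 nM, which is a limit of the assay and not a number. Compound 2 (`O=C1C=CC2(C=C1)OCC(=O)N2S(=O)(=O)c1ccccc1OC(F)(F)F`) gives > 10000 nM, also a limit. Within the data shown here, the only measured step is a step that the two limits leave unreadable from compound 1 to compound 2, and the evidence stops at the limit of > 10000 nM in this assay, at which 2 of the 2 values shown sit. Compound 3 (`O=C1C=CC2(C=C1)OCC(=O)N2S(=O)(=O)c1ccc(Br)s1`) is still unmeasured. Its change from compound 1 is 5-bromothiophen-2-yl in place of phenyl on a sulfonyl sulfur. Among the measured compounds shown here, no measured step covers this replacement, so there is no size to carry over to this assay. A reading at the same limit remains likely, and any shift is expected to be modest and toward stronger inhibition. The estimated step is an at least 1.6-fold lower number from compound 1 to compound 3 (0.22 log units; that floor lies within the scatter). For compound 3 the expected value is 6000 nM, with an estimated range of 800 nM to 20000 nM.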

Compound 3, half-maximal inhibitory concentration: 240 nM
For compound 3 the middle estimate is 25-fold (1.40 log units) above the measured one; measured number below the stated range.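

In this assay, replacing phenyl with 5-bromothiophen-2-yl on the sulfonyl sulfur gives an at least 41-fold lower number from compound 1 to compound 3 (1.61 log units; beyond the scatter), so this position can carry a large change in the read-out, which the earlier pair could not show. On these data alone, compound 1 gives > 10000 nM, which is a limit and not a number, so the true size of this step remains unknown. Compound 3 is the only compound shown with a readable number, and the others stay at the limit: the limit of > 10000 nM in this assay, at which 2 of the 3 values shown sit.

The compounds shown do not separate the contribution of the bromine from that of the thiophene ring; an unsubstituted thiophen-2-yl or a bromophenyl on the same sulfonyl sulfur would address this. As far as these compounds go, the step from compound 1 to compound 2 cannot be read, and whether a chlorine, a methyl group or an amine could stand in place of the bromine also remains open.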